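Benzofuran to furan at the five-membered ring carbon

A few compounds are considered here, and "the series" means these few. Any claim that something is new, unique, unknown or untested is made for them only; others in the source may bear on it.

Of the compounds shown here, two have been measured in a functional assay on K562 cells (Homo sapiens), read by MTT assay, with a stated time of 72 h; a lower number here means a stronger inhibitor, a higher number a weaker inhibitor. Compound 1 `COc1ncnc2c1c(-c1cccs1)cn2[C@@H]1O[C@H](CO)[C@@H](O)[C@H]1O` gives 6200 nM, and compound 2 `COc1ncnc2c1c(-c1cc3ccccc3o1)cn2[C@@H]1O[C@H](CO)[C@@H](O)[C@H]1O` gives 13100 nM. For the measured compounds named here, the one comparable step is a 2.1-fold higher number from compound 1 to compound 2 (0.32 log units; beyond the scatter), so compound 2 stands with the highest of the two numbers, its nearest neighbour being compound 1 at a lower value. Compound 3 `COc1ncnc2c1c(-c1ccco1)cn2[C@@H]1O[C@H](CO)[C@@H](O)[C@H]1O` is not yet measured; it differs from compound 2 in furan-2-yl in place of 1-benzofuran-2-yl on an aromatic carbon. The step from compound 1 to compound 2 bears on this change, since it already showed the 1-benzofuran-2-yl group carrying a modestly higher number than a smaller five-membered ring at the same carbon. Going back to a single five-membered ring with one hetero atom is therefore expected to reverse that modest step, giving a lower number for compound 3, roughly of the size a 1.9-fold lower number from compound 2 to compound 3 (0.27 log units; within the scatter). The estimate for compound 3 in this assay is 7000 nM, with a range from 3000 nM to 16000 nM.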

Compound 3, half-maximal inhibitory concentration: 380 nM
Compound 3: the middle estimate sits 18-fold (1.27 log units) above what was measured, outside the stated range (below it).
By their numbers in this assay, from the lowest: compound 3; then compound 1; then compound 2.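

In this assay, the aromatic carbon two ring bonds from the ring nitrogen proves far more sensitive to the attached group than the earlier pair indicated: furan-2-yl in place of 1-benzofuran-2-yl gives a 34-fold lower number from compound 2 to compound 3 (1.54 log units; beyond the scatter) in this series, a much larger change than a 2.1-fold higher number from compound 1 to compound 2 (0.32 log units; beyond the scatter) seen earlier. Loss of the six-membered aromatic ring of carbon only is not the whole story, since furan-2-yl in place of thiophen-2-yl, another single five-membered aromatic ring, still gives a 16-fold lower number from compound 1 to compound 3 (1.21 log units; beyond the scatter) and sets furan-2-yl apart from both other groups. The three compounds therefore show no simple order by group size, with compound 1 going against such a reading, and nothing shown accounts for the large advantage of furan-2-yl.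

The compounds shown leave open whether this low number is specific to furan-2-yl or extends to close relatives such as furan-3-yl, a methyl-substituted furan-2-yl or an oxazole ring. They also leave open how a plain phenyl ring or a short open chain such as ethyl would behave at this carbon.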